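A few compounds are considered here, and "the series" means these few. Any claim that something is new, unique, unknown or untested is made for them only; others in the source may bear on it.

Of the compounds shown here, three have so far been measured in a functional assay on CCRF-CEM cells (Homo sapiens) for inhibition, read by sulforhodamine B assay, with a stated time of 48 h; on this read-out lower numbers stand for stronger inhibition of growth and higher numbers for weaker inhibition of growth. Compound 3 `Nc1cc(N)c2nc(-c3ccccc3)c(NCc3ccc(Cl)c(Cl)c3)nc2c1` gives 132 nM, the lowest of the three numbers. Compound 1 `Nc1cc(N)c2nc(-c3ccccc3)c(Oc3ccc(Cl)c(Cl)c3)nc2c1` gives 2950 nM, and compound 2 `CCOC(=O)[C@H](CCC(=O)O)NC(=O)c1ccc(CNc2nc3cc(N)cc(N)c3nc2-c2ccccc2)cc1` gives 22900 nM; both gaps from compound 3 lie beyond the usual scatter. The next compound, compound 4 `COc1ccc(CNc2nc3cc(N)cc(N)c3nc2-c2ccccc2)cc1OC`, differs from compound 3 in one place: 3,4-dimethoxyphenyl in place of 3,4-dichlorophenyl on a saturated chain carbon bound to a nitrogen on an aromatic ring. For the measured compounds named here, no measured pair shows this exact change, so its effect cannot be read from the data. The expectation is a modest step toward weaker inhibition of growth, a 3.8-fold higher number from compound 3 to compound 4 (0.58 log units; beyond the scatter), in this assay. On that basis compound 4 is estimated to give about 500 nM, with a likely range from 130 nM to 2000 nM.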

Compound 4, concentration for 50% growth inhibition: 3470 nM
For compound 4 the middle estimate is 6.9-fold (0.84 log units) below the measured one, outside the stated range (above it).
By their numbers in this assay, from the lowest: compound 3; then compounds 1 and 4 (each within the scatter of the next); then compound 2.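

In this assay, putting 3,4-dimethoxyphenyl in place of 3,4-dichlorophenyl on a saturated chain carbon bound to a nitrogen on an aromatic ring gives a 26-fold higher number from compound 3 to compound 4 (1.42 log units; beyond the scatter) on the shared core. For the compounds shown here, this is the first comparison here of compounds that differ in one place, and it shows that the groups on this ring can change growth inhibition greatly. No measurement shown explains the large step.

The compounds shown leave open how a plain phenyl, a single chlorine or 3,4-dimethylphenyl would behave here. From the compounds shown here alone, it therefore remains unknown whether losing the chlorines or gaining the methoxy groups drives the step.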